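This account rests on a few compounds, and the source may have more. Where it says the series, first, only, none or still open, it means among the compounds named here.

Measured so far in a functional assay on PC-3 cells (Homo sapiens) for inhibition, read by MTT assay, with a stated time of 24 h; a higher number here means a weaker inhibitor, a lower number a stronger inhibitor:
Compound 1 `C(=N/c1ccccc1)\c1cc(-c2ccccc2)no1` gives > 100000 nM, a limit of the assay.
Compound 2 `FC(F)(F)c1ccc(-c2cc(/C=N/c3ccccc3)on2)cc1` gives 35700 nM.
Compound 3 `CCc1cc2ccccc2nc1-c1cc(-c2ccccc2)no1` gives > 100000 nM, again a limit of the assay.

Compound 3 therefore stands at the limit of > 100000 nM in this assay, at which 2 of the 3 values shown sit, with no number of its own. Going by the values given here, the only measured step is an at least 2.8-fold lower number from compound 1 to compound 2 (0.44 log units; beyond the scatter), which touches a different part of the shared core and does not bear on the change at hand. Compound 4 `CCCCc1cc2ccccc2nc1-c1cc(-c2ccccc2)no1` differs from compound 3 by ethyl in place of hydrogen on a saturated chain carbon, two bonds along the chain from an aromatic carbon. Among the compounds with values here, no measured step covers a change of this kind, so no shift beyond the scatter is expected in this assay. Compound 4 is expected to remain at the limit as well, with an estimate of 100000 nM (30000 nM to 300000 nM). This estimate means an expected step of a number no higher from compound 3 to compound 4 (the limit leaves the size open).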

Compound 4, half-maximal inhibitory concentration: > 100000 nM
Compound 4 was reported as a limit; the forecaster's own chance of this, stated with the estimate: 70%; the middle value lies on the limit itself.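

Compound 3 and compound 4 both stand at the limit of this assay, so the step between them cannot be read. The compounds shown leave open whether going from ethyl to butyl on this core changes inhibition at all.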